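A few compounds are considered here, and "the series" means these few. Any claim that something is new, unique, unknown or untested is made for them only; others in the source may bear on it.

Measured so far in a physicochemical assay for solubility, read by LC-MS, in phosphate buffer, with a stated time of 24 h, at pH 7.4; on this read-out lower numbers stand for lower solubility and higher numbers for higher solubility:
compound 1 `CN(c1ccccc1)c1cnc(NCc2c(F)ccc3c2CCO3)n2cnnc12` — < 2000 nM.
compound 2 `CN(c1ncco1)c1cnc(NCc2c(F)ccc3c2CCO3)n2cnnc12` — 67000 nM.
compound 3 `CN(c1cccnc1)c1cnc(NCc2c(F)ccc3c2CCO3)n2cnnc12` — 47000 nM.

The value of compound 1 is only a limit of this assay, (the limit of < 2000 nM in this assay, at which 1 of the 3 values shown sits). Compound 3 stands at the lowest of the two real numbers, with compound 2 nearest: a 1.4-fold lower number from compound 2 to compound 3 (0.15 log units; within the scatter). Compound 4 `COCCC(=O)Nc1cnc(NCc2c(F)ccc3c2CCO3)n2cnnc12` differs from compound 3 in one place: ((2-methoxyethyl)carbonyl)amino in place of methyl(pyridin-3-yl)amino on an aromatic carbon. The measured steps each exchange one aromatic ring for another on the nitrogen: an at least 33-fold higher number from compound 1 to compound 2 (1.52 log units; beyond the scatter) and an at least 23-fold higher number from compound 1 to compound 3 (1.37 log units; beyond the scatter) were large, while the step between the two heteroaryl compounds was within the scatter. Among the compounds with values here, no measured step exchanges the whole amino group for an amide chain, so these steps bear only loosely on the change. The step expected for compound 4 is a 1.7-fold higher number from compound 3 to compound 4 (0.23 log units; within the scatter). Compound 4 is estimated at 80000 nM, in a range from 20000 nM to 300000 nM.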

Compound 4, solubility: 980000 nM
Compound 4: the middle estimate sits 12-fold (1.09 log units) below what was measured; measured number outside the range, above it.
By their numbers in this assay, from the lowest: compounds 3 and 2 (each within the scatter of the next); then compound 4. At a limit, below all of these: compound 1.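

Replacing methyl(pyridin-3-yl)amino on this aromatic carbon with the ringless ((2-methoxyethyl)carbonyl)amino chain moves the number in this assay much further than the exchange between the two heteroaryl groups did, with a 21-fold higher number from compound 3 to compound 4 (1.32 log units; beyond the scatter) and a 15-fold higher number from compound 2 to compound 4 (1.17 log units; beyond the scatter) both large. An aromatic ring on the nitrogen at this position is therefore not needed for a high number. Against the phenyl compound there is an at least 490-fold higher number from compound 1 to compound 4 (2.69 log units; beyond the scatter), a step resting on a limit: the limit of < 2000 nM in this assay, at which 1 of the 4 values shown sits. Still open, on these data alone, is whether the amide carbonyl or the methoxyethyl end goes with the higher number. A shorter acetyl amide, a longer ether chain or a terminal carboxylic acid on the same carbon would separate these.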